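Removing a Methoxy Group from a Fused Bicyclic Core

This account rests on a few compounds, and the source may have more. Where it says the series, first, only, none or still open, it means among the compounds named here.

Compounds measured so far:
compound 1, `COc1nn2cc(-c3cc4c(OC)ccc(OC)c4o3)nc2s1`: 28%
compound 2, `COc1cc(OCc2cccc(O)c2)c2cc(-c3cn4nc(OC)sc4n3)oc2c1`: 49%

Two compounds sharing a common core have been examined in an ADME assay on microsomes from liver (Rattus norvegicus) for metabolic stability, with a stated time of 10 min; on this read-out lower numbers stand for a less stable compound and higher numbers for a more stable compound. Compound 1, `COc1nn2cc(-c3cc4c(OC)ccc(OC)c4o3)nc2s1`, gives 28% in this assay, the lower of the two numbers. Compound 2, `COc1cc(OCc2cccc(O)c2)c2cc(-c3cn4nc(OC)sc4n3)oc2c1`, gives 49% in this assay, a number that sits beyond the usual scatter above that of compound 1. Since these two differ in more than one place, only their two values can be compared.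

Compound 3, `COc1nn2cc(-c3cc4c(OC)cccc4o3)nc2s1`, is not yet measured. It differs from compound 1 in a single place: hydrogen in place of methoxy on an aromatic carbon. Among the compounds with values here, no measured pair shows the effect of such a change, so the expectation rests on compound 1 alone. A small rise is expected, with the step from compound 1 to compound 3, a number 8 percentage points higher from compound 1 to compound 3 (within the scatter), judged to lie near the edge of the scatter. Compound 3 is therefore estimated at 36%, with a range from 20% to 55%.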

Compound 3, percent of the compound remaining: 42%
For compound 3 the middle estimate is 6 percentage points below the measured one; low and high end bracket the measured number.
By their numbers in this assay, from the lowest: compound 1; then compounds 3 and 2 (each within the scatter of the next).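

Within the data shown here, compound 1 and compound 3 form the first pair that isolates this change: in this assay, hydrogen in place of methoxy gives a number 14 percentage points higher from compound 1 to compound 3 (beyond the scatter) on an otherwise unchanged structure. The methoxy group on this aromatic carbon, para to a methoxy group that remains in compound 3, is therefore not needed to keep the read-out at the level of compound 1, and the number rises once it is gone. This holds for this one position and this one pair, and a single step gives no trend.

As far as these compounds go, whether fluorine, an amine or a longer alkoxy chain at this position would give a higher or lower number than hydrogen remains open, as does whether removing the remaining methoxy group would produce a similar step. Nothing available accounts for the size or direction of this step.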